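This account rests on a few compounds, and the source may have more. Where it says the series, first, only, none or still open, it means among the compounds named here.

Measured compounds:
compound 1 `C=C1C(=O)O[C@]2(C)CC[C@@H]1C[C@H](O)[C@@]1(C)CC[C@H](O1)C(=C)CC[C@H]2OC(C)=O`: > 20 ug/mL
compound 2 `C=C1C(=O)O[C@]2(C)CC[C@@H]1C[C@H](OC(C)=O)[C@@]1(C)CC[C@H](O1)C(=C)CC[C@H]2OC(C)=O`: > 20 ug/mL
compound 3 `C=C1C(=O)O[C@]2(C)CC[C@@H]1C[C@H](O)[C@@]1(C)CC[C@H](O1)[C@](C)(O)CCC2=O`: > 20 ug/mL

All three were tested in a functional assay on Doay cells (Homo sapiens) for cytotoxicity; on this read-out higher numbers stand for weaker inhibition and lower numbers for stronger inhibition. In this assay compound 1 gives > 20 ug/mL, which is a limit of the assay and not a number. Compound 2 likewise gives > 20 ug/mL, again a limit. Compound 3 gives > 20 ug/mL, also a limit. Compound 2 differs from compound 1 by acetyl in place of hydrogen on an oxygen on a saturated carbon, and the step that the two limits leave unreadable from compound 1 to compound 2 cannot be read, because the limit of > 20 ug/mL in this assay, at which 3 of the 3 values shown sit, hides any difference between the two. Compound 3 and compound 1 differ in more than one place; the difference between the two cores is not broken down here.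

Compound 4 `C=C1C(=O)O[C@]2(C)CC[C@@H]1C[C@H](OC(C)=O)[C@@]1(C)CC[C@H](O1)[C@](C)(O)CCC2=O` is not yet measured. Going by the values given here, it differs from compound 3 by acetyl in place of hydrogen on an oxygen on a saturated carbon, the same change, at a place described in the same words, as the one from compound 1 to compound 2. The step is expected to be a step that the limit leaves unreadable from compound 3 to compound 4, resting on the unreadable step that the two limits leave unreadable from compound 1 to compound 2 and on (the limit of > 20 ug/mL in this assay, at which 3 of the 3 values shown sit), which leaves no sign that this change moves the read-out. Compound 4 is therefore estimated at 25 ug/mL, with a wide range from 10 ug/mL to 60 ug/mL.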

Compound 4, half-maximal inhibitory concentration: > 20 ug/mL
Compound 4 ended at the assay's limit; the forecaster's own chance of this, stated with the estimate: 85%; the middle value is on the limit's open side.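

In this assay compound 4 gives > 20 ug/mL, which is a limit of the assay and not a number. The change from compound 3 to compound 4, hydroxy to acetoxy, cannot be read, because all the compounds end the same way: the limit of > 20 ug/mL in this assay, at which 4 of the 4 values shown sit. The compounds shown leave open what real value any of them has in this assay, and so whether hydroxy to acetoxy moves the read-out on either core.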